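Series notes: amine change on the chain carbon of compound 2

The compounds below may be only part of what the source reports. "The series", "measured", "known", "first", "only" and "open" are said of these compounds alone.

Of the compounds shown here, two have been measured in a functional assay on MDA-MB-468 cells (Homo sapiens) for cytotoxicity, read by sulforhodamine B assay, with a stated time of 48 h; on this read-out lower numbers stand for stronger inhibition of growth and higher numbers for weaker inhibition of growth. Compound 1 `Cc1ccc2nc(/N=C3\C(=O)N(CN(C)C)c4ccccc43)sc2c1` gives 35500 nM. Compound 2 `CCN(CC)CN1C(=O)/C(=N\c2nc3ccc(C)cc3s2)c2c(Cl)cccc21` gives 27300 nM, the lower of the two numbers, though the gap to compound 1 lies within the scatter, so no order between them is claimed.

Compound 3 `Cc1ccc2nc(/N=C3\C(=O)N(CN(C)C)c4cccc(Cl)c43)sc2c1` is not yet measured. It differs from compound 2 in one place: dimethylamino in place of diethylamino on a saturated chain carbon bound to an amide-type nitrogen in a ring. Going by the values given here, no pair of measured compounds shows this change, so no measured step guides the expectation. The two measured numbers, which differ in more than this one place, sit close together, and the step from compound 2 to compound 3 is therefore expected to be small, a 1.1-fold higher number from compound 2 to compound 3 (0.04 log units; within the scatter), not beyond the scatter in either direction. Compound 3 is expected to give about 30000 nM, with a range from 12000 nM to 75000 nM.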

Compound 3, concentration for 50% growth inhibition: 28100 nM
Compound 3: middle estimate off by 1.1-fold (0.03 log units), on the high side; measured number inside the range.
By their numbers in this assay, from the lowest: compounds 2, 3 and 1 (each within the scatter of the next).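

Notes on the amine change: in this assay, dimethylamino in place of diethylamino on a saturated chain carbon bound to an amide-type nitrogen in a ring now has a direct reading (a 1.0-fold higher number from compound 2 to compound 3 (0.01 log units; within the scatter)), and this swap leaves the number within the scatter. Compound 3 also isolates chloro in place of hydrogen on an aromatic carbon (a 1.3-fold lower number from compound 1 to compound 3 (0.10 log units; within the scatter)), again within the scatter, a reading that compound 1 and compound 2 could not give while they differed in more than one place. No measurement at hand explains either step.

Still open, going by these compounds, is whether a cyclic amine such as morpholine or piperidine in place of these open-chain amines, or a longer chain carrying the amine, would move the number beyond the scatter. Equally open, on these data alone, is whether fluoro or methoxy in place of chloro would do so.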